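Phthalimide-triazole thioethers: a fourth analogue at the cytotoxicity limit

The source may hold more compounds than are shown below. What is called first, only, known or untested is meant among the compounds shown, and "the series" means these compounds.

Of the compounds shown here, three sharing one core have been tested in a functional assay on HepG2 cells (Homo sapiens) for cytotoxicity, read by MTT assay, with a stated time of 48 h (on this read-out lower numbers stand for stronger inhibition and higher numbers for weaker inhibition), and none gave a number. Compound 1 `Cc1nnc(SCc2ccccc2)n1N1C(=O)c2ccccc2C1=O` returned only the assay limit of > 200000 nM in this assay. Compound 2 `Cc1nnc(SCC(=O)c2ccccc2)n1N1C(=O)c2ccccc2C1=O` likewise sits at the limit, > 200000 nM in this assay. Among the compounds with values here, the single step among them, a step that the two limits leave unreadable from compound 1 to compound 2, is therefore unreadable. Compound 3 `C#CCSc1nnc(CC)n1N1C(=O)c2ccccc2C1=O` also reaches only the limit of > 200000 nM in this assay, so its standing is known only as one of the three values at the limit of > 200000 nM in this assay, at which 3 of the 3 values shown sit.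

Compound 4 `CCc1nnc(SCC(=O)c2ccc(Cl)cc2)n1N1C(=O)c2ccccc2C1=O` differs from compound 3 by (4-chlorophenyl)carbonyl in place of ethynyl on a saturated chain carbon bound to a sulfur. Within the data shown here, the only measured step that touches a change on that same chain carbon, from compound 1 to compound 2, is hidden by two limits, so it offers no readable size. With all three values at the limit, compound 4 is expected to remain there, with the step that the limit leaves unreadable from compound 3 to compound 4 estimated as none beyond the scatter. Compound 4 is expected to give about 250000 nM in this assay, estimated between 100000 nM and 1000000 nM, most likely as a limit again.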

Compound 4, half-maximal inhibitory concentration: > 200000 nM
Compound 4: no number, only a limit; the forecaster's own chance of this, stated with the estimate: 85%; the middle value is on the limit's open side.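

Compound 4 returns only a limit, > 200000 nM in this assay, and since compound 3 also stands at a limit, no new step can be read. The compounds shown leave open whether any change on a saturated chain carbon bound to a sulfur alters this read-out: the limit of > 200000 nM in this assay, at which 4 of the 4 values shown sit.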